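Bromo for methoxy on the benzyl ring of compound 1

The source may hold more compounds than are shown below. What is called first, only, known or untested is meant among the compounds shown, and "the series" means these compounds.

Among the compounds with values here, in a functional assay on HepG2 cells (Homo sapiens) for cytotoxicity, read by MTT assay, with a stated time of 48 h (a lower number here means a stronger inhibitor, a higher number a weaker inhibitor), compound 1 `CCCCOC(=O)/C=C/c1ccc2c(c1)C(=O)C(=O)N2Cc1ccc(OC)cc1` gives 630 nM, the highest of the three numbers so far. Compound 2 `COC(=O)/C=C/c1ccc2c(c1)C(=O)C(=O)N2Cc1ccc(OC)cc1` gives 30 nM, and compound 3 `COc1ccc(CN2C(=O)C(=O)c3cc(/C=C/C(=O)OC(C)(C)C)ccc32)cc1` gives 620 nM. The measured steps are a 21-fold lower number from compound 1 to compound 2 (1.32 log units; beyond the scatter), a 1.0-fold lower number from compound 1 to compound 3 (0.01 log units; within the scatter) and a 21-fold higher number from compound 2 to compound 3 (1.32 log units; beyond the scatter); each of them alters only the group on the oxygen next to the carbonyl group. Compound 4 `CCCCOC(=O)/C=C/c1ccc2c(c1)C(=O)C(=O)N2Cc1ccc(Br)cc1` keeps that butyl ester and changes a different part of the molecule: bromo in place of methoxy on an aromatic carbon. No measured step touches the benzyl ring, so nothing among the numbers shown argues for a shift beyond the scatter in either direction. Compound 4 is therefore expected to stay close to compound 1, with an estimated no change at the digits printed from compound 1 to compound 4 (within the scatter), giving 630 nM within a range of 250 nM to 1600 nM.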

Compound 4, half-maximal inhibitory concentration: 650 nM
Compound 4: the middle estimate sits 1.0-fold (0.01 log units) below what was measured; measured number inside the range.
By their numbers in this assay, from the lowest: compound 2; then compounds 3, 1 and 4 (each within the scatter of the next).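

Holding the butyl ester fixed, the exchange of 4-methoxybenzyl for 4-bromobenzyl gives a 1.0-fold higher number from compound 1 to compound 4 (0.01 log units; within the scatter) in this assay as the first reading at the benzyl ring. On this butyl ester, the aromatic carbon para to a large group therefore accepts bromo in place of methoxy without a shift beyond the scatter. No supporting data bear on why the two groups read alike.

From the compounds shown here alone, whether this flat reading carries over to the methyl ester of compound 2 remains open. So does the response to an amine or a carboxylic acid at this ring position.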